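A few compounds are considered here, and "the series" means these few. Any claim that something is new, unique, unknown or untested is made for them only; others in the source may bear on it.

Measured compounds:
- compound 1 `c1cc(Nc2nccc(-c3ccco3)n2)cc(-n2ccnc2)c1` gives 800 nM in a functional assay for inhibition, with Homo sapiens as the target; on this read-out higher numbers stand for weaker inhibition and lower numbers for stronger inhibition
- compound 2 `c1ccc(Nc2nccc(-c3ccco3)n2)cc1` gives 32000 nM in this assay
- compound 3 `CC1CCN(c2cccc(Nc3nccc(-c4ccco4)n3)c2)CC1` gives 5000 nM in this assay

Compound 3 stands second highest of the three numbers: below compound 2 and above compound 1. The step of a 6.4-fold lower number from compound 2 to compound 3 (0.81 log units; beyond the scatter) shows that adding the 4-methylpiperidin-1-yl to the bare ring of compound 2 lowers the number, while a 6.3-fold higher number from compound 1 to compound 3 (0.80 log units; beyond the scatter) shows it falls well short of the imidazolyl of compound 1. The full weight of that imidazolyl is seen in a 40-fold higher number from compound 1 to compound 2 (1.60 log units; beyond the scatter).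

Compound 4 `CCc1cccc(Nc2nccc(-c3ccco3)n2)c1` is the next step: ethyl in place of 4-methylpiperidin-1-yl on an aromatic carbon. The bearing steps are the two that remove or exchange the substituent at this carbon. Ethyl carries no ring and no acceptor, so compound 4 is expected to give back part of the gain seen in a 6.4-fold lower number from compound 2 to compound 3 (0.81 log units; beyond the scatter) and to sit between compound 2 and compound 3 in this assay. The estimated step is a 2.4-fold higher number from compound 3 to compound 4 (0.38 log units; beyond the scatter), a modest rise. Compound 4 is estimated at 12000 nM, with a range of 4000 nM to 40000 nM.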

Compound 4, half-maximal inhibitory concentration: 9700 nM
Estimate against measurement, compound 4: 1.2-fold (0.09 log units) above, and the stated range covers the measured number.
By their numbers in this assay, from the lowest: compound 1; then compounds 3 and 4 (each within the scatter of the next); then compound 2.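

In this assay the step of a 1.9-fold higher number from compound 3 to compound 4 (0.29 log units; within the scatter) does not separate ethyl from 4-methylpiperidin-1-yl on this aromatic carbon, so in this pair the ring and hydrogen-bond acceptor of the larger group add nothing that can be read. Ethyl, with no ring and no acceptor, still counts against hydrogen in the step of a 3.3-fold lower number from compound 2 to compound 4 (0.52 log units; beyond the scatter) and so accounts for a gain on its own. For the compounds shown here, the step of a 12-fold higher number from compound 1 to compound 4 (1.08 log units; beyond the scatter) sets 1H-imidazol-1-yl clearly apart from ethyl, as it is from 4-methylpiperidin-1-yl and hydrogen in the earlier steps.

Nothing at hand bears on the cause of these steps.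
Open, on these data alone, is whether a methyl, a longer carbon chain, an open-chain amine or a carboxylic acid on this carbon would stay with ethyl or approach 1H-imidazol-1-yl.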